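Replacing the 4-bromobutyl group of compound 1

The source may hold more compounds than are shown below. What is called first, only, known or untested is meant among the compounds shown, and "the series" means these compounds.

Measured so far in a functional assay on HL-60 cells (Homo sapiens) for cytotoxicity, read by MTT assay, with a stated time of 24 h; on this read-out higher numbers stand for weaker inhibition and lower numbers for stronger inhibition:
Compound 1 `BrCCCCOc1c(Br)cc(Br)cc1Oc1ccc(Br)cc1Br` gives 25.9 ug/mL
Compound 2 `OCCCOc1c(Br)cc(Br)cc1Oc1ccc(Br)cc1Br` gives 29.9 ug/mL

The values of compound 1 and compound 2 lie within the scatter of each other, so compound 1 holds no separate place on these numbers. Compound 3 `CC(C)(C)C(=O)C(C#N)Oc1c(Br)cc(Br)cc1Oc1ccc(Br)cc1Br` has not yet been measured. It differs from compound 1 by having cyano((tert-butyl)carbonyl)methyl in place of 4-bromobutyl on an oxygen on an aromatic ring and shares the rest of its core. Among the compounds with values here, only one measured step bears on this change, and only in part: the step of a 1.2-fold higher number from compound 1 to compound 2 (0.06 log units; within the scatter) alters the end of the same chain and stays within the scatter. Within the data shown here, it says nothing direct about the entering group, which no measured compound carries. On this thin basis, no step beyond the scatter is expected in this assay in either direction, although the uncertainty is wide. The estimated step is a 1.0-fold lower number from compound 1 to compound 3 (0.02 log units; within the scatter) and remains a loose expectation. For compound 3 the expected value is 25 ug/mL within an estimated range of 10 ug/mL to 60 ug/mL overall.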

Compound 3, half-maximal inhibitory concentration: 29.2 ug/mL
Beside the measured number, compound 3's estimate is 1.2-fold (0.07 log units) below it; the range from low to high includes it.
By their numbers in this assay, from the lowest: compounds 1, 3 and 2 (each within the scatter of the next).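

In this assay, the change on the oxygen on an aromatic ring goes well beyond the end of the chain: 4-bromobutyl gives way to cyano((tert-butyl)carbonyl)methyl, which has no bromine and brings in a carbonyl and a nitrile, yet the result is a 1.1-fold higher number from compound 1 to compound 3 (0.05 log units; within the scatter). Against the 3-hydroxypropyl group, the same entering group gives a 1.0-fold lower number from compound 2 to compound 3 (0.01 log units; within the scatter), so the three groups on this oxygen, which end in bromine, hydroxy and a branched chain carrying a carbonyl and a nitrile, all lie within the scatter of one another on the shared core. The data at hand offer no account of why such different groups read alike.

From the compounds shown here alone, it remains open whether any group on this oxygen would move the number beyond the scatter, for instance an amine or a carboxylic acid at the end of the chain, or a simple hydroxy on the ring with no chain at all. These compounds also leave open whether the same flat reading would hold on a different core, since all three share one.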